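Adding a trifluoromethyl group to compound 3

The source may report more compounds than this note shows. Statements on the series, on what has been measured and on what is new or still open speak of the compounds shown alone.

In an ADME assay on the whole organism (plasma) for pharmacokinetics, with Rattus norvegicus as the target, with a stated time of 6 h, at a dose of 10 mg/kg by the oral route (on this read-out higher numbers stand for higher exposure at the dose given and lower numbers for lower exposure), compound 1 `Nc1ccc(CS(=O)(=O)N2CCN(c3cnn(-c4cc(F)cc(F)c4)c(=O)c3OC3CCCC3)CC2)cc1` gives 8100 ng.h/mL, compound 2 `Nc1cccc(CS(=O)(=O)N2CCN(c3cnn(-c4cc(F)cc(F)c4)c(=O)c3OC3CCCC3)CC2)c1` gives 5700 ng.h/mL, and compound 3 `CC1(COc2c(N3CCN(S(=O)(=O)Cc4ccc(N)cc4)CC3)cnn(-c3cccc(Cl)c3)c2=O)CC1` gives 8100 ng.h/mL. Compound 3 therefore stands level with compound 1, and compound 2 lies within the usual scatter of both.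

Compound 4 `CC1(COc2c(N3CCN(S(=O)(=O)Cc4ccc(N)c(C(F)(F)F)c4)CC3)cnn(-c3cccc(Cl)c3)c2=O)CC1` differs from compound 3 in one place: trifluoromethyl in place of hydrogen on an aromatic carbon. Trifluoromethyl takes the place of hydrogen on an aromatic carbon, ortho to an amino group, so 4-aminophenyl becomes 4-amino-3-(trifluoromethyl)phenyl.

Among the measured compounds shown here, only one measured step touches this ring: a 1.4-fold lower number from compound 1 to compound 2 (0.15 log units; within the scatter). That step moves the amino group and adds nothing to the ring, so it is only a loose guide. For the measured compounds named here, no measured compound carries this new group, so the data give no direction for the change. A step beyond the scatter in this assay is therefore not expected, although the uncertainty is wide. The expected step is a 1.2-fold lower number from compound 3 to compound 4 (0.06 log units; within the scatter). For compound 4 the estimate is 7000 ng.h/mL, with an expected range from 2500 ng.h/mL to 20000 ng.h/mL.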

Compound 4, area under the concentration-time curve: 640 ng.h/mL
For compound 4 the middle estimate is 11-fold (1.04 log units) above the measured one; measured number outside the range, below it.
By their numbers in this assay, from the lowest: compound 4; then compounds 2, 1 and 3 (each within the scatter of the next).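

In this assay, the aromatic carbon ortho to an amino group proves sensitive to substitution: trifluoromethyl in place of hydrogen there gives a 13-fold lower number from compound 3 to compound 4 (1.10 log units; beyond the scatter), a large step. Among the compounds shown here, the only earlier step, a 1.4-fold lower number from compound 1 to compound 2 (0.15 log units; within the scatter), moved the amino group around the ring and added nothing to it, so it gave no sign that one added group on this ring could change exposure this much. What lies behind the drop cannot be told, as nothing here bears on its cause.

Going by these compounds, whether a fluorine atom, a methyl group or a nitrile at the same place would lower the number as far remains open. On these data alone, it is also open whether trifluoromethyl would do the same on the core of compound 1, since this step comes from a single pair.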